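Swapping a rigid pyridine tail for a flexible phenylthio chain

The compounds below may be only part of what the source reports. "The series", "measured", "known", "first", "only" and "open" are said of these compounds alone.

Of the compounds shown here, three sharing one core have been tested in an assay for inhibition of Fatty-acid amide hydrolase 1 (Rattus norvegicus); on this read-out lower numbers stand for stronger inhibition and higher numbers for weaker inhibition. Compound 1 `O=C(CCCCC#Cc1ccccn1)c1ncc(-c2ccccn2)o1` gives 280 nM, the highest of the three numbers shown. Compound 2 `O=C(CCCCC#Cc1ccc([N+](=O)[O-])cc1)c1ncc(-c2ccccn2)o1` gives 31 nM, and compound 3 `O=C(CSCCCCc1ccccc1)c1ncc(-c2ccccn2)o1` gives 4 nM. Going by the values given here, the one measured step, a 9.0-fold lower number from compound 1 to compound 2 (0.96 log units; beyond the scatter), shows that replacing the pyridine tail of compound 1 with a carbon-only ring moves the number well downward. Compound 4 `O=C(CCCCCSc1ccccc1)c1ncc(-c2ccccn2)o1` takes a different route from compound 1: (phenylsulfanyl)methyl in place of 2-(pyridin-2-yl)ethynyl on a saturated chain carbon, four bonds along the chain from a carbonyl carbon. This change also removes the pyridine ring and introduces a sulfur-containing chain; compound 3, which likewise carries a sulfur in its chain and a phenyl ring, shows a far lower number than compound 1. A downward step is therefore expected, a 23-fold lower number from compound 1 to compound 4 (1.37 log units; beyond the scatter), with compound 4 estimated at 12 nM, likely between 3 nM and 50 nM.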

Compound 4, inhibition constant: 3 nM
Compound 4: the middle estimate sits 4.0-fold (0.60 log units) above what was measured; the measured number falls inside the stated range.
By their numbers in this assay, from the lowest: compounds 4 and 3 (each within the scatter of the next); then compound 2; then compound 1.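

The whole 2-(pyridin-2-yl)ethynyl group can be exchanged at this place for (phenylsulfanyl)methyl, of equal heavy-atom count, with a 93-fold lower number from compound 1 to compound 4 (1.97 log units; beyond the scatter) as the outcome. Unlike the earlier step from compound 1, this one removes the triple bond and brings in sulfur, so the chain itself, and not only the ring at its end, can be changed. Nothing shown explains the size of this step.

Going by these compounds, because the ring, triple bond and sulfur change together, their separate shares remain unknown. A phenylethynyl or phenoxymethyl group at this place would help to separate them.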